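Pyrrolidine Sulfonamide Weighed Against Its Open-Chain Parent

The source may report more compounds than this note shows. Statements on the series, on what has been measured and on what is new or still open speak of the compounds shown alone.

Measured in an assay on a protein complex (Cavia porcellus) with sulfonylurea receptors; K-ATP channels (Homo sapiens) as the target; on this read-out lower numbers stand for stronger inhibition and higher numbers for weaker inhibition:
compound 1 `CCN(CC)S(=O)(=O)c1ccc(NC(=O)C(C)(O)C(F)(F)F)cc1`: 810 nM
compound 2 `CC(O)(C(=O)Nc1ccc(S(=O)(=O)N2CCOCC2)cc1)C(F)(F)F`: 5850 nM
Not yet measured: compound 3 `CC(O)(C(=O)Nc1ccc(S(=O)(=O)N2CCCC2)cc1)C(F)(F)F`

Compound 1 holds the lower of the two numbers in this assay, with compound 2 standing a 7.2-fold higher number from compound 1 to compound 2 (0.86 log units; beyond the scatter). Compound 3 differs from compound 1 by pyrrolidin-1-yl in place of diethylamino on a sulfonyl sulfur. For the measured compounds named here, only the step from compound 1 to compound 2 speaks to a ring closing on that sulfonyl nitrogen, and it was a modest weakening. Compound 3 is therefore expected to give a number somewhat higher than compound 1, by about a 1.9-fold higher number from compound 1 to compound 3 (0.27 log units; within the scatter). Compound 3 is estimated at 1500 nM, between 500 nM and 4500 nM.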

Compound 3, half-maximal inhibitory concentration: 880 nM
Compound 3: middle estimate off by 1.7-fold (0.23 log units), on the high side; measured number inside the range.
By their numbers in this assay, from the lowest: compounds 1 and 3 (each within the scatter of the next); then compound 2.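

In this assay, pyrrolidin-1-yl in place of diethylamino on a sulfonyl sulfur gives a 1.1-fold higher number from compound 1 to compound 3 (0.04 log units; within the scatter) and so shows that a ring on that sulfonyl nitrogen can sit within the scatter of the open-chain compound. The weakening seen with compound 2 therefore does not follow from ring closure alone, as pyrrolidin-1-yl in place of morpholin-4-yl gives a 6.6-fold lower number from compound 2 to compound 3 (0.82 log units; beyond the scatter) in the same assay. No supporting data explain this gap between the two rings. As far as these compounds go, whether piperidin-1-yl would fall with compound 3 or with compound 2 remains open, as does the outcome with a longer chain such as dipropylamino.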